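The source may report more compounds than this note shows. Statements on the series, on what has been measured and on what is new or still open speak of the compounds shown alone.

Measured compounds:
compound 1, `O=c1cc(-c2ccccc2)oc2ccc(N3COc4ccccc4C3)cc12`: 68.5%
compound 2, `COc1cccc2c1OCN(c1ccc3oc(-c4ccccc4)cc(=O)c3c1)C2`: 67.8%

Both were tested in a functional assay on MCF7 cells (Homo sapiens) for inhibition, read by MTT assay, with a stated time of 48 h, tested at 30 ug/mL; a higher number here means more inhibition of growth at the concentration tested, a lower number less inhibition of growth. For the measured compounds named here, of the two numbers, compound 1 sits at the top, but the only measured step, a number 0.7 percentage points lower from compound 1 to compound 2 (within the scatter), lies within the scatter, so compound 1 and compound 2 cannot be told apart on these data.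

Compound 3, `Cc1ccc2c(c1)CN(c1ccc3oc(-c4ccccc4)cc(=O)c3c1)CO2`, is the next compound in line and differs from compound 1 in one place: methyl in place of hydrogen on an aromatic carbon. Going by the values given here, the one step measured so far, a methoxy in place of hydrogen on an aromatic carbon of the same part of the shared core, is the only guide, and it was within the scatter. A methyl entering at an aromatic carbon of that ring is therefore expected to leave the number much where compound 1 stands, with an expected step of a number 1.5 percentage points lower from compound 1 to compound 3 (within the scatter) that does not go beyond the scatter. Compound 3 is expected to give about 67%, within a range from 55% to 78%.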

Compound 3, percent growth inhibition at one concentration: 56.9%
Compound 3: the middle estimate sits 10.1 percentage points above what was measured; the range from low to high includes it.
By their numbers in this assay, from the lowest: compound 3; then compounds 2 and 1 (each within the scatter of the next).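

Measured in this assay, a single methyl in place of hydrogen on an aromatic carbon of this ring gives a modest step that goes beyond the scatter (a number 11.6 percentage points lower from compound 1 to compound 3 (beyond the scatter)), so substitution on this ring can change growth inhibition. The earlier methoxy in place of hydrogen stayed within the scatter (a number 0.7 percentage points lower from compound 1 to compound 2 (within the scatter)), and these two steps cannot separate the effect of the group from the effect of the carbon that carries it. No measurement at hand accounts for the lower number of compound 3.

As far as these compounds go, it remains open whether a methyl on the other aromatic carbons of this ring would give a similar step. From the compounds shown here alone, it is also open whether a chlorine, an amine or a carboxylic acid on the carbon that carries the methyl would lower the number further or bring it back towards that of compound 1.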